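The compounds below may be only part of what the source reports. "The series", "measured", "known", "first", "only" and "open" are said of these compounds alone.

Going by the values given here, compound 3 `CC1=C(N2CC2)C(=O)C(CCCc2ccccc2)=C(N2CC2)C1=O` is the lowest of the three compounds measured so far in a functional assay on L1210 cells (Mus musculus), with a stated time of 1 days; on this read-out higher numbers stand for higher potency (the scale is a negative logarithm) and lower numbers for lower potency: compound 1 `CC1=C(N2CC2)C(=O)C(CC(C)OC(N)=O)=C(N2CC2)C1=O` gives 5.18, compound 2 `COCCC1=C(N2CC2)C(=O)C(C)=C(N2CC2)C1=O` gives 5.12, and compound 3 gives 3.6. Compound 4 `CC1=C(N2CC2)C(=O)C(CCC(=O)N(C)C)=C(N2CC2)C1=O` has not yet been measured; it differs from compound 3 by dimethylcarbamoyl in place of benzyl on a saturated chain carbon, two bonds along the chain from a double-bonded ring carbon. Among the compounds with values here, two measured steps bear on this change. Both introduce the benzyl-bearing group, and both show large losses: a number 1.58 log units lower from compound 1 to compound 3 (beyond the scatter) and a number 1.52 log units lower from compound 2 to compound 3 (beyond the scatter). For compound 4 the expected step is a number 1.40 log units higher from compound 3 to compound 4 (beyond the scatter), a large rise, since the benzyl leaves and a group without a ring enters, as found in compound 1 and compound 2. Compound 4 is therefore estimated at 5, with a range from 4.4 to 5.5.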

Compound 4, logarithm of the reciprocal of the active concentration, log(1/C): 4.84
Compound 4: the middle estimate sits 0.16 log units above what was measured; low and high end bracket the measured number.
By their numbers in this assay, from the lowest: compound 3; then compounds 4, 2 and 1 (each within the scatter of the next, the first and the last beyond it).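

In this assay (this assay), exchanging benzyl for dimethylcarbamoyl gives a clear recovery (a number 1.24 log units higher from compound 3 to compound 4 (beyond the scatter)). This new ringless group stays close to the methoxy of compound 2 (a number 0.28 log units lower from compound 2 to compound 4 (within the scatter)) and falls only modestly short of the ringless side chain of compound 1 (a number 0.34 log units lower from compound 1 to compound 4 (beyond the scatter)), so all three ringless compounds stand well above the phenyl-bearing compound 3. No measurement is available to explain this difference.

As far as these compounds go, whether the aromatic ring itself goes with the low number stays open. A plain butyl chain, a cyclohexyl ring or a carboxylic acid at this place could help to settle that.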